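The source may hold more compounds than are shown below. What is called first, only, known or untested is meant among the compounds shown, and "the series" means these compounds.

Compound 1 `CC1(C)C=C(n2ccccc2=O)c2ccccc2O1` carries only a hydrogen at the aromatic carbon of interest, and in a functional assay (trachea) with Rattus norvegicus as the target (a lower number here means a less potent compound, a higher number a more potent compound, by a factor of ten per unit of this negative logarithm), compound 1 gives 5.05. Within the data shown here, compound 2 `CC1(C)C=C(n2ccccc2=O)c2cc(C(=N)NO)ccc2O1` has a larger group in that position; in this assay compound 2 gives 5.51, which is the higher of the two numbers measured so far, the difference being a number 0.46 log units higher from compound 1 to compound 2 (beyond the scatter). Compound 3 `CC1(C)C=C(n2ccccc2=O)c2cc(C=O)ccc2O1` is the next member to be examined. The change is a group of 2 heavy atoms (1 carbon, 1 oxygen; no ring) in place of a group of 4 heavy atoms (1 carbon, 2 nitrogen, 1 oxygen; no ring), on an aromatic carbon. Among the measured compounds shown here, only one measured step speaks to this change: the gain of a number 0.46 log units higher from compound 1 to compound 2 (beyond the scatter) when that group replaced a hydrogen. A formyl is neither that group nor a bare hydrogen, so compound 3 is expected to fall between the two measured neighbours, and the step of a number 0.31 log units lower from compound 2 to compound 3 (beyond the scatter) is expected to be small, possibly inside the usual scatter. Compound 3 is therefore estimated at 5.2, with a likely range from 4.7 to 5.7.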

Compound 3, logarithm of the reciprocal of the active concentration, log(1/C): 6.14
The estimate for compound 3 lay 0.94 log units below the measured number; the measured number lies above the stated range.
By their numbers in this assay, from the lowest: compound 1; then compound 2; then compound 3.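

In this assay the formyl, the smaller of the two groups, does more at this aromatic carbon than the group it replaces, with a number 0.63 log units higher from compound 2 to compound 3 (beyond the scatter), so a gain here does not require the larger group or its hydrogen-bond donors, as the formyl has none. Measured against the bare hydrogen, the formyl gives a number 1.09 log units higher from compound 1 to compound 3 (beyond the scatter), whereas the other group gave only a number 0.46 log units higher from compound 1 to compound 2 (beyond the scatter), so the size of the gain depends on which group sits at this carbon. No measurement available here explains why the formyl does better.

On these data alone, with only a hydrogen and two groups compared at this carbon, it remains open whether a nitrile, an acetyl group or a carboxylic acid would match the formyl. As far as these compounds go, it is also open whether a formyl would give a similar gain elsewhere on the same aromatic ring.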